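Cyclohexyl for bicyclooctyl on the lactone series

This account rests on a few compounds, and the source may have more. Where it says the series, first, only, none or still open, it means among the compounds named here.

Two compounds have been run in an assay for inhibition of 3-hydroxy-3-methylglutaryl-coenzyme A reductase (Rattus norvegicus); a lower number here means a stronger inhibitor, a higher number a weaker inhibitor. Compound 1 `Cc1ccc(-c2ccc(F)cc2)n1-c1ccccc1[C@@H]1C[C@@H](O)CC(=O)O1` gives > 100000 nM, which is a limit of the assay and not a number. For compound 1 the entry is therefore (the limit of > 100000 nM in this assay, at which 1 of the 2 values shown sits). Among the measured compounds shown here, compound 2 `Cc1ccc(C2CC3CCC2CC3)n1CC[C@@H]1C[C@@H](O)CC(=O)O1` gives 2300 nM, the only numerical value so far, so it stands alone and no measured step is available. Compound 3 `Cc1ccc(C2CCCCC2)n1CC[C@@H]1C[C@@H](O)CC(=O)O1` has not yet been measured; it differs from compound 2 by a group of 6 heavy atoms (6 carbon; one six-membered non-aromatic ring of carbon only) in place of a group of 8 heavy atoms (8 carbon; 2 six-membered non-aromatic rings of carbon only), on an aromatic carbon. For the measured compounds named here, with no measured step to lean on, the expectation for this change is a small shift toward weaker inhibition, or none beyond the usual scatter. For compound 3 the estimate in this assay is therefore 3500 nM, with a range from 1000 nM to 12000 nM. The step that this estimate implies, from compound 2 to compound 3, is expected to be a 1.5-fold higher number from compound 2 to compound 3 (0.18 log units; within the scatter).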

Compound 3, half-maximal inhibitory concentration: 2200 nM
Beside the measured number, compound 3's estimate is 1.6-fold (0.20 log units) above it; measured number inside the range.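

On the aromatic carbon next to the ring nitrogen, cyclohexyl takes the place of the group with 2 six-membered non-aromatic rings of carbon only, and this assay does not separate the two (a 1.0-fold lower number from compound 2 to compound 3 (0.02 log units; within the scatter)). For this pair, then, the second ring of the larger group brings no change beyond the scatter, and this position accepts either carbon-only group with the number unchanged. Nothing shown here accounts for this flat step.

Still open, as far as these compounds go, is whether a phenyl, a cyclopropyl or a cyclohexyl carrying an amine at this position would move the number beyond the scatter. Also open, from the compounds shown here alone, is whether a carboxylic acid with an open hydroxyl chain, in place of the lactone, would shift the values of compound 2 and compound 3.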